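A few compounds are considered here, and "the series" means these few. Any claim that something is new, unique, unknown or untested is made for them only; others in the source may bear on it.

Compound 1, `CCCCc1cc2cn([C@H]3C[C@H](O)[C@@H](CO)O3)c(=O)nc2s1`: in a functional assay on HEL cells (Homo sapiens) for cytotoxicity, read by microscopy (on this read-out lower numbers stand for higher toxicity in this test and higher numbers for lower toxicity in this test), compound 1 gives >= 100000 nM, which is a limit of the assay and not a number.
Compound 2, `CCCCCCCCc1cc2cn([C@H]3C[C@H](O)[C@@H](CO)O3)c(=O)nc2s1`: in this assay compound 2 gives 20000 nM.

Within the data shown here, compound 2 therefore holds the only actual number in this small set; the other entry sits at the limit of >= 100000 nM in this assay, at which 1 of the 2 values shown sits, so nothing can be said about how far apart the two truly lie beyond what the single step shows. That step, an at least 5.0-fold lower number from compound 1 to compound 2 (0.69 log units; beyond the scatter), was a change in one place only: a butyl entered where a hydrogen had been on the saturated chain, and the minimum cytotoxic concentration fell beyond the usual scatter, meaning more toxicity toward the cells.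

Compound 3, `CCCCCCCCCCc1cc2cn([C@H]3C[C@H](O)[C@@H](CO)O3)c(=O)nc2s1`, carries the same kind of change once more, now further out: ethyl in place of hydrogen on a saturated chain carbon, eight bonds along the chain from an aromatic carbon. Among the measured compounds shown here, the only measured step that bears on it is the one just described, and it was at least modest. The new change adds fewer carbons than that step did, so a smaller drop in the read-out is expected, a 2.0-fold lower number from compound 2 to compound 3 (0.30 log units; within the scatter). Compound 3 is thus estimated at 10000 nM, within a range from 3000 nM to 30000 nM.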

Compound 3, minimum cytotoxic concentration: 20000 nM
Beside the measured number, compound 3's estimate is 2.0-fold (0.30 log units) below it; low and high end bracket the measured number.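

In this assay, the ethyl added eight bonds along the chain from an aromatic carbon gives no change at the digits printed from compound 2 to compound 3 (within the scatter), so the clear step seen between the first two compounds does not repeat with this further extension. Taken as a whole, placing hexyl on the saturated chain carbon four bonds along the chain from an aromatic carbon still gives an at least 5.0-fold lower number from compound 1 to compound 3 (0.69 log units; beyond the scatter), which means that both longer chains stand apart from compound 1 by a margin beyond the scatter, while compound 2 and compound 3 cannot be told apart. The entry for compound 1 is a limit and not a number, so the full size of that step stays unknown: the limit of >= 100000 nM in this assay, at which 1 of the 3 values shown sits.

On these data alone, whether a still longer chain, such as dodecyl, would match compound 2 and compound 3 or differ from them remains open. Also open, as far as these compounds go, is what this same position would show if the chain ended in an amine or a carboxylic acid, since every chain in this set is a plain carbon chain.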